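The compounds below may be only part of what the source reports. "The series", "measured", "known", "first", "only" and "open" are said of these compounds alone.

Of the compounds shown here, two have so far been measured in a functional assay on CHO cells for antagonist activity at growth hormone secretagogue receptor type 1 (Homo sapiens); a higher number here means a weaker inhibitor, a lower number a stronger inhibitor. Compound 1 `COc1ccc(-n2c(CCc3ccccc3)nnc2[C@H](NC(=O)c2ccccn2)c2c[nH]c3ccccc23)c(OC)c1` gives 65 nM in this assay, and compound 2 `CCc1ccc(Cn2c(CCc3ccccc3)nnc2[C@H](NC(=O)c2ccccn2)c2c[nH]c3ccccc23)cc1` gives 513 nM. For the measured compounds named here, compound 1 therefore holds the lower of the two numbers; the single recorded step, a 7.9-fold higher number from compound 1 to compound 2 (0.90 log units; beyond the scatter), concerns only the substituent on the aromatic nitrogen and lies beyond the scatter.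

Compound 3 `COc1ccc(-n2c(CCc3ccccc3)nnc2[C@H](NC(=O)Cc2ccccn2)c2c[nH]c3ccccc23)c(OC)c1` keeps the core and the aromatic-nitrogen substituent of compound 1 and alters the amide side instead: (pyridin-2-yl)methyl in place of pyridin-2-yl on a carbonyl carbon. Going by the values given here, no measured pair touches this carbonyl substituent, so the step from compound 1 to compound 2 gives no direct guide. Among the compounds with values here, it shows only that a single change elsewhere in this scaffold moved this assay by a modest amount, and a change of similar extent is expected here, most likely toward a higher number. For compound 3 the expected step in this assay is a 3.1-fold higher number from compound 1 to compound 3 (0.49 log units; beyond the scatter). Compound 3 is accordingly estimated at 200 nM in this assay, with a range from 60 nM to 700 nM.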

Compound 3, antagonist equilibrium constant: 35 nM
Compound 3: middle estimate off by 5.7-fold (0.76 log units), on the high side; measured number below the stated range.
By their numbers in this assay, from the lowest: compounds 3 and 1 (each within the scatter of the next); then compound 2.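

On the carbonyl carbon whose other neighbour is an amide-type nitrogen, (pyridin-2-yl)methyl in place of pyridin-2-yl gives a 1.9-fold lower number from compound 1 to compound 3 (0.27 log units; within the scatter) in this assay, so the pyridin-2-yl group need not stand directly on the carbonyl carbon for the number to stay within the scatter of that of compound 1. The substituent on the aromatic nitrogen behaves differently in this small set, since 4-ethylbenzyl in place of 2,4-dimethoxyphenyl gives a 7.9-fold higher number from compound 1 to compound 2 (0.90 log units; beyond the scatter) in the same assay, a step beyond the scatter, whereas the carbonyl change stays within it. Nothing available accounts for this tolerance at the carbonyl substituent.

The compounds shown leave open how far this tolerance extends, for example to a longer chain such as 2-(pyridin-2-yl)ethyl, to a plain phenyl or benzyl group, or to a pyridin-3-yl isomer on the same carbonyl carbon. They also leave open whether (pyridin-2-yl)methyl on the carbonyl carbon and 4-ethylbenzyl on the aromatic nitrogen would act independently when combined in one compound.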